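Mirror image of an inactive stereoisomer

The compounds below may be only part of what the source reports. "The series", "measured", "known", "first", "only" and "open" are said of these compounds alone.

Compound 1 `CN1C[C@@H](Nc2nc3cc[nH]c3c(=O)n2C)C[C@@H](c2ccccc2)C1` was examined in an assay on isolated protein for binding affinity to histone acetyltransferase KAT2B (Homo sapiens), read by isothermal titration calorimetry; on this read-out lower numbers stand for tighter binding and higher numbers for weaker binding. In this assay compound 1 gives only a limit, > 10000 nM, so its binding is not resolved into a number; this is recorded as the limit of > 10000 nM in this assay, at which 1 of the 2 values shown sits. Compound 2 `CN1C[C@H](Nc2nc3cc[nH]c3c(=O)n2C)C[C@H](c2ccc(O)cc2)C1` was also tested, and in this assay compound 2 gives 120 nM. Compound 3 `CN1C[C@H](Nc2nc3cc[nH]c3c(=O)n2C)C[C@H](c2ccccc2)C1` has not been measured. It differs from compound 1 as follows: the two compounds have the same atoms and bonds and differ only in configuration as drawn: 2 of 2 stereo elements differ (all stereocentres are inverted: mirror images); a stereocentre at a saturated ring carbon is drawn S in compound 1 and R in compound 3; a stereocentre at a saturated ring carbon is drawn S in compound 1 and R in compound 3. Going by the values given here, no measured step between two compounds of this set is available to calibrate the effect of such an inversion, so the expectation rests on the values alone. Compound 2 shows that the core with both ring stereocentres drawn R can bind tightly, and compound 3 shares that configuration. Compound 3 is therefore expected to bind more tightly than compound 1, with the step from compound 1 to compound 3 estimated at an at least 16-fold lower number from compound 1 to compound 3 (1.22 log units; beyond the scatter). The estimate for compound 3 in this assay is 600 nM, with a range from 100 nM to 5000 nM.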

Compound 3, dissociation constant: 152 nM
For compound 3 the middle estimate is 3.9-fold (0.60 log units) above the measured one; low and high end bracket the measured number.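

Inverting both ring stereocentres, with nothing else changed, gives an at least 65-fold lower number from compound 1 to compound 3 (1.81 log units; beyond the scatter) in this assay, so configuration alone decides whether this core shows resolved binding: the fact that compounds 1 and 3 differ only in the configuration as drawn. The figure for compound 1 is a limit of the assay and not a number, so the true size of this step stays unresolved: the limit of > 10000 nM in this assay, at which 1 of the 3 values shown sits. With the configuration of compound 2 kept, hydrogen in place of hydroxy on an aromatic carbon gives a 1.3-fold higher number from compound 2 to compound 3 (0.10 log units; within the scatter), so in this pair the hydroxy group is not needed for the binding seen.

From the compounds shown here alone, the two inversions appear only together, so what each stereocentre contributes alone remains open. Also open, going by these compounds, is how a methoxy group, a fluorine atom or an amine on that aromatic carbon would compare with hydrogen and hydroxy.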